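The compounds below may be only part of what the source reports. "The series", "measured", "known", "first", "only" and "open" are said of these compounds alone.

Measured so far in a physicochemical assay for solubility, with a stated time of 18 h, at pH 7.4; on this read-out lower numbers stand for lower solubility and higher numbers for higher solubility:
- compound 1 `COc1ccccc1Oc1ccc2c(NCCCNCc3ccco3)ccnc2c1`: 14500 nM
- compound 2 `COc1ccc(F)cc1CNCCCNc1ccnc2cc(Cc3ccc(C#N)cc3)ccc12`: 4200 nM
- compound 3 `c1coc(CNCCCNc2ccnc3cc(C4CCCCC4)ccc23)c1`: 4200 nM

On these numbers compound 3 stands level with compound 2 at the digits shown, the two together being the lowest, while compound 1 sits higher by a 3.5-fold lower number from compound 1 to compound 3 (0.54 log units; beyond the scatter).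

Compound 4 `N#Cc1ccc(Cc2ccc3c(NCCCNCc4ccco4)ccnc3c2)cc1` has not yet been measured. It differs from compound 3 in one place: 4-cyanobenzyl in place of cyclohexyl on an aromatic carbon.

Within the data shown here, the one measured step, a 3.5-fold lower number from compound 1 to compound 3 (0.54 log units; beyond the scatter), concerns the same position but a different group, so it does not directly settle this change. Compound 2 carries the same 4-cyanobenzyl group at that position and gives 4200 nM, the same reading as compound 3. Little change beyond the scatter is therefore expected, and compound 4 is estimated at 4500 nM, range 1800 nM to 11000 nM, a step of a 1.1-fold higher number from compound 3 to compound 4 (0.03 log units; within the scatter).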

Compound 4, solubility: 4200 nM
The estimate for compound 4 lay 1.1-fold (0.03 log units) above the measured number; measured number inside the range.
By their numbers in this assay, from the lowest: compounds 2, 3 and 4 (each within the scatter of the next); then compound 1.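

In this assay, 4-cyanobenzyl in place of cyclohexyl on the aromatic carbon gives no change at the digits printed from compound 3 to compound 4 (within the scatter), so these two groups cannot be told apart at this position. Furan-2-yl in place of 5-fluoro-2-methoxyphenyl on the chain carbon gives no change at the digits printed from compound 2 to compound 4 (within the scatter), while 4-cyanobenzyl in place of 2-methoxyphenoxy gives a 3.5-fold lower number from compound 1 to compound 4 (0.54 log units; beyond the scatter), leaving compound 1 as the only one that stands apart. No evidence is at hand to explain these readings. On these data alone, whether an amine or a carboxylic acid on this aromatic carbon would shift the number beyond the scatter remains open.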